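Trading one five-membered ring for another

The source may hold more compounds than are shown below. What is called first, only, known or untested is meant among the compounds shown, and "the series" means these compounds.

Three compounds share one core and differ only in the ring on an aromatic carbon. In a functional assay on DU-145 cells (Homo sapiens), read by sulforhodamine B assay, with a stated time of 5 days (on this read-out lower numbers stand for stronger inhibition of growth and higher numbers for weaker inhibition of growth), compound 1 `OC[C@H]1O[C@@H](n2cc(F)c3c(-c4ccccc4)ncnc32)[C@H](O)[C@@H]1O`, with phenyl, gives 580 nM. Compound 2 `OC[C@H]1O[C@@H](n2cc(F)c3c(-c4cccs4)ncnc32)[C@H](O)[C@@H]1O`, with thiophen-2-yl, gives 9 nM, and compound 3 `OC[C@H]1O[C@@H](n2cc(F)c3c(-c4nccs4)ncnc32)[C@H](O)[C@@H]1O`, with 1,3-thiazol-2-yl, gives 24 nM. That makes compound 3 the second highest of the three numbers.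

Compound 4 `OC[C@H]1O[C@@H](n2cc(F)c3c(-c4ccc[nH]4)ncnc32)[C@H](O)[C@@H]1O` has 1H-pyrrol-2-yl in place of 1,3-thiazol-2-yl on an aromatic carbon. Leaving phenyl for a five-membered aromatic ring brought large steps, a 64-fold lower number from compound 1 to compound 2 (1.81 log units; beyond the scatter) and a 24-fold lower number from compound 1 to compound 3 (1.38 log units; beyond the scatter). Exchanging one five-membered ring for another brought only a modest step, a 2.7-fold higher number from compound 2 to compound 3 (0.43 log units; beyond the scatter). Compound 4 keeps a five-membered aromatic ring, so no step beyond the scatter is expected in this assay. The expected change is a 1.5-fold higher number from compound 3 to compound 4 (0.16 log units; within the scatter). No measured ring has a hydrogen-bond donor, so the range is kept wide. For compound 4 the estimate is 35 nM, with an expected range of 8 nM to 150 nM.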

Compound 4, concentration for 50% growth inhibition: 9 nM
Estimate against measurement, compound 4: 3.9-fold (0.59 log units) above, and the stated range covers the measured number.
By their numbers in this assay, from the lowest: compounds 2 and 4 (each within the scatter of the next); then compound 3; then compound 1.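

In this assay, within the data shown here, 1H-pyrrol-2-yl is the first ring here to carry a hydrogen-bond donor, and it shows that such a ring can sit on this aromatic carbon with a 2.7-fold lower number from compound 3 to compound 4 (0.43 log units; beyond the scatter) and with no change at the digits printed from compound 2 to compound 4 (within the scatter) as well. All three five-membered rings now stand clear of phenyl, with a 64-fold lower number from compound 1 to compound 4 (1.81 log units; beyond the scatter) joining the two large steps seen before, while 1,3-thiazol-2-yl stays apart from the other two rings by a modest margin. Nothing measured here explains why these ring exchanges move the number as they do. Going by these compounds, whether the hydrogen on the pyrrole nitrogen matters remains open, and 1-methylpyrrol-2-yl would test that directly. Furan-2-yl, an amine or a short alkyl chain on this carbon could show how far the low numbers depend on a five-membered aromatic ring.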